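A few compounds are considered here, and "the series" means these few. Any claim that something is new, unique, unknown or untested is made for them only; others in the source may bear on it.

Measured compounds:
compound 1 `CN(c1ccc(Oc2ncnc3ccsc23)cc1)c1nccc(N2CCCCC2)n1` gives 66.2% in a functional assay on HCT-116 cells (Homo sapiens) for inhibition, read by MTT assay, with a stated time of 72 h, tested at 20 uM; a lower number here means less inhibition, a higher number more inhibition at the concentration tested (going by the name of the read-out)
compound 2 `c1cc(N2CCCCC2)nc(Nc2ccc(Oc3ncnc4ccsc34)cc2)n1` gives 61.5% in this assay
compound 3 `c1ccc2c(c1)CCN2c1ccnc(Nc2ccc(Oc3ncnc4sccc34)cc2)n1` gives -0.62% in this assay

Compound 3 stands lowest of the three numbers in this assay; the difference between the core of compound 3 and the core of compound 2 is not broken down here. Within the pair compound 2 and compound 1, the change methyl in place of hydrogen on a nitrogen on an aromatic ring makes the step of a number 4.7 percentage points higher from compound 2 to compound 1 (within the scatter). The same change, (methyl in place of hydrogen on a nitrogen on an aromatic ring), leads from compound 3 to compound 4 `CN(c1ccc(Oc2ncnc3sccc23)cc1)c1nccc(N2CCc3ccccc32)n1`, which is not yet measured in this assay. For the measured compounds named here, since that change left the number essentially unchanged in the one instance where it was measured, compound 4 is expected to stay close to compound 3, with a step estimated at a number 5.6 percentage points higher from compound 3 to compound 4 (within the scatter). The estimate for compound 4 in this assay is therefore 5%, with a range from -10% to 25%.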

Compound 4, a percentage reported as inhibition, at one concentration (the size of the read-out at that concentration, not a potency): 20%
Compound 4: the middle estimate sits 15 percentage points below what was measured, and the stated range covers the measured number.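

In this assay, methyl in place of hydrogen on a nitrogen on an aromatic ring makes the step of a number 20.6 percentage points higher from compound 3 to compound 4 (beyond the scatter). The size of the step does not carry over unchanged from one core to the other: the same change on two cores in this assay, a number 4.7 percentage points higher (within the scatter) from compound 2 to compound 1 and a number 20.6 percentage points higher (beyond the scatter) from compound 3 to compound 4, 15.9 percentage points apart, beyond the scatter of two such steps. For the compounds shown here, two cores show only that the step can differ with the core; they do not show which part of the core sets its size, or what size to expect on a further core.

Still open, from the compounds shown here alone, is whether a longer chain on that nitrogen, such as ethyl, or an acetyl group would differ between the two cores in the same way. Single-concentration percentages also leave potency unread.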